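The source may hold more compounds than are shown below. What is called first, only, known or untested is meant among the compounds shown, and "the series" means these compounds.

Measured so far:
compound 1 `CCCn1c(=O)[nH]c2nc(-c3ccc(S(=O)(=O)N4CCN(c5ccc(Br)cc5)CC4)cc3)[nH]c2c1=O` — 8%
compound 2 `CCCn1c(=O)[nH]c2nc(-c3ccc(S(=O)(=O)N4CCN(Cc5cccc(Br)c5)CC4)cc3)[nH]c2c1=O` — 5%

In an assay on CHO cells for displacement of a labelled ligand from adenosine receptor A3 (Mus musculus), read by scintillation counting, with a stated time of 180 min, tested at 1 uM, in the presence of a further agent that is not named here (a higher number here means more inhibition at the concentration tested (going by the name of the read-out), a lower number less inhibition), compound 2 gives 5%, the lower of the two numbers in hand, though its nearest neighbour compound 1 with 8% lies within the scatter, the step being a number 3 percentage points lower from compound 1 to compound 2 (within the scatter). Compound 3 `CCCn1c(=O)[nH]c2nc(-c3ccc(S(=O)(=O)N4CCN(c5cccc(F)c5)CC4)cc3)[nH]c2c1=O` differs from compound 2 by 3-fluorophenyl in place of 3-bromobenzyl on an amine nitrogen in a ring. Among the measured compounds shown here, the only measured step that bears on this change is a number 3 percentage points lower from compound 1 to compound 2 (within the scatter), which put 3-bromobenzyl where 4-bromophenyl stood on the same ring nitrogen without moving the number beyond the scatter. No step beyond the scatter is therefore expected for a number 1 percentage points higher from compound 2 to compound 3 (within the scatter). Compound 3 is expected to give 6%, between -4% and 17%.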

Compound 3, a percentage reported as inhibition, at one concentration (the size of the read-out at that concentration, not a potency): -2%
The estimate for compound 3 lay 8 percentage points above the measured number, within the range that was stated.
By their numbers in this assay, from the lowest: compounds 3, 2 and 1 (each within the scatter of the next).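

In this assay, a number 7 percentage points lower from compound 2 to compound 3 (within the scatter) and a number 10 percentage points lower from compound 1 to compound 3 (within the scatter) add a third group on this ring nitrogen without any step beyond the scatter. The change from 3-bromobenzyl or 4-bromophenyl to 3-fluorophenyl therefore gives no separation, so these three groups cannot be ranked at this position. Nothing available accounts for these numbers.

Still open, as far as these compounds go, is whether a carboxylic acid, an amine or a longer chain on this ring nitrogen would move the number beyond the scatter of these three compounds.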